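Replacing (oxan-4-yl)methyl with 4-methoxycyclohexyl on the shared core

The source may report more compounds than this note shows. Statements on the series, on what has been measured and on what is new or still open speak of the compounds shown alone.

Measured so far in an ADME assay on the whole organism for pharmacokinetics, with Rattus norvegicus as the target, at a dose of 5 mg/kg by the oral route (a lower number here means less compound in the circulation, a higher number more compound in the circulation at the dose given), for two compounds
- compound 1 `Cc1nc(-c2nc[nH]n2)ccc1-c1cnc2c(n1)N([C@H]1CC[C@@H](O)CC1)C(=O)CN2` gives 28.5 ng.h/mL here
- compound 2 `Cc1nc(-c2nc[nH]n2)ccc1-c1cnc2c(n1)N(CC1CCOCC1)C(=O)CN2` gives 1080 ng.h/mL here

Compound 2 stands highest of these two. Next comes compound 3 `CO[C@H]1CC[C@H](N2C(=O)CNc3ncc(-c4ccc(-c5nc[nH]n5)nc4C)nc32)CC1` with this change: 4-methoxycyclohexyl in place of (oxan-4-yl)methyl on an amide-type nitrogen in a ring on the same ring nitrogen. Within the data shown here, one measured step bears on it, namely a 38-fold higher number from compound 1 to compound 2 (1.58 log units; beyond the scatter) when (oxan-4-yl)methyl replaced 4-hydroxycyclohexyl. Compound 3 brings back a cyclohexyl ring, but with methoxy in place of the hydroxy of compound 1. That single step cannot show how much of its size belongs to the ring and how much to the hydroxy. A partial return towards compound 1 is therefore expected, giving a lower number but not the full drop. The expected move is a 2.7-fold lower number from compound 2 to compound 3 (0.43 log units; beyond the scatter) in this estimate. Compound 3 is expected at 400 ng.h/mL with an estimated range from 90 ng.h/mL to 1700 ng.h/mL in this assay when measured.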

Compound 3, area under the concentration-time curve: 2930 ng.h/mL
The estimate for compound 3 lay 7.3-fold (0.86 log units) below the measured number; measured number outside the range, above it.
By their numbers in this assay, from the lowest: compound 1; then compound 2; then compound 3.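

In this assay, a cyclohexyl ring on this amide-type nitrogen does not by itself hold the number down: 4-methoxycyclohexyl in place of (oxan-4-yl)methyl gives a 2.7-fold higher number from compound 2 to compound 3 (0.43 log units; beyond the scatter). Among these compounds, the low number of compound 1 goes with the hydroxy on the ring rather than with the ring, since changing only 4-hydroxycyclohexyl to 4-methoxycyclohexyl gives a 100-fold higher number from compound 1 to compound 3 (2.01 log units; beyond the scatter). Nothing measured alongside these numbers tells what lies behind either step.

The compounds shown leave open whether the number stays high with a longer chain on the ring oxygen, as in 4-ethoxycyclohexyl, or falls with an amine or a carboxylic acid at the same ring position. They also leave open whether the higher numbers reflect more compound entering the circulation, slower removal from it, or both.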